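A few compounds are considered here, and "the series" means these few. Any claim that something is new, unique, unknown or untested is made for them only; others in the source may bear on it.

In a functional assay on A2780 cells (Homo sapiens) for antiproliferative activity (a higher number here means a weaker inhibitor, a lower number a stronger inhibitor), compound 1 `CN(C)C(=O)N1Cc2cc(Cl)ccc2C(c2cccc(O)c2)C1` gives 1190 nM and compound 2 `CN(C)C(=O)N1Cc2cc(Br)ccc2C(c2cccc(O)c2)C1` gives 879 nM with the two values level within the scatter. Compound 3 `CN(C)C(=O)N1Cc2cc(I)ccc2C(c2cccc(O)c2)C1` carries iodo in place of bromo on an aromatic carbon, a change from compound 2 counted as iodo in place of bromo on an aromatic carbon and nothing more. Going by the values given here, the one measured step that bears on it, also an exchange of one halogen for another, is a 1.4-fold lower number from compound 1 to compound 2 (0.13 log units; within the scatter) and it stays within the scatter. No step beyond the scatter is therefore expected in this assay for this change. The expected step is a 1.1-fold lower number from compound 2 to compound 3 (0.04 log units; within the scatter) in this estimate. Compound 3 is expected at 800 nM within an estimated range of 350 nM to 1700 nM in this measurement.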

Compound 3, half-maximal inhibitory concentration: 363 nM
For compound 3 the middle estimate is 2.2-fold (0.34 log units) above the measured one; measured number inside the range.
By their numbers in this assay, from the lowest: compound 3; then compounds 2 and 1 (each within the scatter of the next).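

In this assay this position on the aromatic ring proves responsive to the choice of halogen: iodo in place of bromo gives a 2.4-fold lower number from compound 2 to compound 3 (0.38 log units; beyond the scatter) and iodo in place of chloro gives a 3.3-fold lower number from compound 1 to compound 3 (0.52 log units; beyond the scatter), whereas the exchange of chloro for bromo stayed within the scatter. Among these three halogens, only iodo stands apart from the others. No evidence at hand explains this difference.
From the compounds shown here alone, whether the lower number is particular to iodo remains open, as a nitrile, a methoxy group or an amine at this carbon would test. Also open, going by these compounds, is whether the same step holds with another group in place of the hydroxyl on the second aromatic ring.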